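Para-Chloro on a Sulfonamide Aryl Ring: Two Pairs Compared

This account rests on a few compounds, and the source may have more. Where it says the series, first, only, none or still open, it means among the compounds named here.

This account concerns four compounds that share one core and differ in the chain that links it to an aryl sulfonamide. Compound 1 `CC(C)c1ccc2c(CNC(=O)CNS(=O)(=O)c3ccccc3)cc(C(=O)O)c-2cc1` and compound 2 `CC(C)c1ccc2c(CNC(=O)CNS(=O)(=O)c3ccc(Cl)cc3)cc(C(=O)O)c-2cc1` carry the sulfonamide reversed relative to compound 3 `CC(C)c1ccc2c(CCCCCS(=O)(=O)Nc3ccccc3)cc(C(=O)O)c-2cc1` and compound 4 `CC(C)c1ccc2c(CCCCCS(=O)(=O)Nc3ccc(Cl)cc3)cc(C(=O)O)c-2cc1`. The difference between the core-to-aryl linkage of compound 1 and that of compound 3 is not broken down here.

In a functional assay on thoracic aorta for antagonist activity at thromboxane A2 receptor (Rattus norvegicus) (a lower number here means a stronger inhibitor, a higher number a weaker inhibitor), compound 1 gives only a limit, > 100000 nM. Compound 2 likewise gives only a limit, > 100000 nM. The step that the two limits leave unreadable from compound 1 to compound 2 is therefore of unknown size, because both values sit at the limit of > 100000 nM in this assay, at which 2 of the 3 values shown sit. Compound 3, by contrast, gives a number in this assay, 1500 nM.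

The change from compound 3 to compound 4 is chloro in place of hydrogen on an aromatic carbon, and from compound 1 to compound 2 it is chloro in place of hydrogen on an aromatic carbon. The two place lines read the same, so this is the same change made on two different linkers; the difference one bond further out is phenylsulfonyl to (4-chlorophenyl)sulfonyl in one pair and anilino to (4-chlorophenyl)amino in the other.

Since the measured pair gives no readable size, the expectation for compound 4 rests only on compound 3 and its value 1500 nM. Compound 4 is expected to land near compound 3 in this assay, with an estimated step of no change at the digits printed from compound 3 to compound 4 (within the scatter). The estimate for compound 4 is 1500 nM, expected to fall between 500 nM and 4500 nM.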

Compound 4, half-maximal inhibitory concentration: 1700 nM
Compound 4: the middle estimate sits 1.1-fold (0.05 log units) below what was measured; the measured number falls inside the stated range.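

In this assay, chloro in place of hydrogen on an aromatic carbon gives a 1.1-fold higher number from compound 3 to compound 4 (0.05 log units; within the scatter), so on this linker the change leaves the reading within the scatter. The same change on the other linker cannot be sized, and the two pairs cannot be compared, because compound 1 and compound 2 each give only a limit of the assay: the limit of > 100000 nM in this assay, at which 2 of the 4 values shown sit. Within the data shown here, compound 3 and compound 4 are therefore the only pair here that gives a size, so this single pair shows the change on one linker only and does not show that it would read the same on the linker of compound 1 or on any other core.

Still open, on these data alone, is whether a group other than chloro at this place on the ring, such as fluoro, methoxy, an amine or a carboxylic acid, would read differently from hydrogen on either linker. Also open, as far as these compounds go, is whether the result for chloro would hold on a shorter or longer chain than that of compound 3, and how the linker of compound 1 would read with a group that lifts its values off the limit.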